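Side chain change on the dichlorophenyl compound

A few compounds are considered here, and "the series" means these few. Any claim that something is new, unique, unknown or untested is made for them only; others in the source may bear on it.

In a functional assay on HCT-116 cells (Homo sapiens) for antiproliferative activity, read by sulforhodamine B assay, with a stated time of 72 h (on this read-out higher numbers stand for weaker inhibition and lower numbers for stronger inhibition), compound 2 `Cn1ncc(Cl)c1-c1cc(C(=O)N[C@@H]2CN[C@H](CC(O)CO)C[C@H]2c2ccc(Cl)c(Cl)c2)oc1Cl` gives 1110 nM and lies within the scatter of compound 1 `Cn1ncc(Cl)c1-c1cc(C(=O)N[C@@H]2CN[C@H](CC(O)CO)C[C@H]2c2ccc(F)c(F)c2)oc1Cl` at 800 nM while compound 3 `Cn1ncc(Cl)c1-c1cc(C(=O)N[C@@H]2CN[C@H](CCO)C[C@H]2c2ccc(F)c(F)c2)oc1Cl` at 360 nM shows a lower number than both. Compound 4 `CN(C)CC[C@@H]1C[C@@H](c2ccc(Cl)c(Cl)c2)[C@H](NC(=O)c2cc(-c3c(Cl)cnn3C)c(Cl)o2)CN1` differs from compound 2 by (dimethylamino)methyl in place of 1,2-dihydroxyethyl on a saturated chain carbon bound to a saturated ring carbon in a change that also reads as 2,3-dihydroxypropyl to 2-(dimethylamino)ethyl. The nearest evidence is a 2.2-fold lower number from compound 1 to compound 3 (0.35 log units; beyond the scatter) on the same chain. The step of a 1.4-fold higher number from compound 1 to compound 2 (0.14 log units; within the scatter) concerns only the aryl group. Within the data shown here, no measured compound carries the new group, so only a modest move to a lower number is expected in this assay with wide uncertainty. The expected step is a 2.5-fold lower number from compound 2 to compound 4 (0.39 log units; beyond the scatter) on this estimate. Compound 4 is estimated at 450 nM with an expected range of 130 nM to 1500 nM for now.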

Compound 4, half-maximal inhibitory concentration: 1710 nM
For compound 4 the middle estimate is 3.8-fold (0.58 log units) below the measured one, and the stated range ends below it.
By their numbers in this assay, from the lowest: compound 3; then compounds 1, 2 and 4 (each within the scatter of the next, the first and the last beyond it).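

In this assay, 2-(dimethylamino)ethyl in place of 2,3-dihydroxypropyl gives a 1.5-fold higher number from compound 2 to compound 4 (0.19 log units; within the scatter), so on the 3,4-dichlorophenyl compounds this chain position accepts a dimethylamino end with no shift beyond the scatter. Among these compounds, this differs from the only earlier chain change, a 2.2-fold lower number from compound 1 to compound 3 (0.35 log units; beyond the scatter), which lies beyond the scatter and was seen with 3,4-difluorophenyl. No data shown explain the result. On these data alone, whether the 2-(dimethylamino)ethyl chain gives the same outcome with 3,4-difluorophenyl remains open. So does the effect of a carboxylic acid or a longer amine chain on this saturated chain carbon.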